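The source may hold more compounds than are shown below. What is called first, only, known or untested is meant among the compounds shown, and "the series" means these compounds.

In a functional assay on HeLa cells (Homo sapiens) for antiproliferative activity, read by CCK-8 assay, with a stated time of 72 h, tested at 8 uM (a lower number here means a weaker effect, a higher number a stronger effect of the compound at the concentration tested), compound 1 `CN1CCN(C(=S)SCc2ccc(C(=O)Nc3ccccc3N)cc2)CC1` gives 75.7%, and compound 2 `Nc1ccccc1NC(=O)c1ccc(CSC(=S)N2CCN(c3ccccc3F)CC2)cc1` gives 59.2%, the lower of the two numbers shown. Within the data shown here, the only step recorded, a number 16.5 percentage points lower from compound 1 to compound 2 (beyond the scatter), is the sole guide for what follows. Compound 3 `Nc1ccccc1NC(=O)c1ccc(CSC(=S)N2CCN(C3CCCCC3)CC2)cc1` differs from compound 2 by cyclohexyl in place of 2-fluorophenyl on an amine nitrogen in a ring. That earlier step concerned a different exchange on the same ring nitrogen, so its direction carries little over to this one, and no step beyond the scatter is expected here. For compound 3 an inhibition of 62% is estimated, within 45% to 78%, meaning an expected step of a number 2.8 percentage points higher from compound 2 to compound 3 (within the scatter).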

Compound 3, a percentage reported as inhibition, at one concentration (the size of the read-out at that concentration, not a potency): 76.1%
Beside the measured number, compound 3's estimate is 14.1 percentage points below it; measured number inside the range.
By their numbers in this assay, from the lowest: compound 2; then compounds 1 and 3 (each within the scatter of the next).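

In this assay the change to cyclohexyl gives a number 16.9 percentage points higher from compound 2 to compound 3 (beyond the scatter) and shows that a carbon ring on this ring nitrogen need not lower the inhibition. Cyclohexyl in place of methyl gives a number 0.4 percentage points higher from compound 1 to compound 3 (within the scatter) and so, among these three compounds, a group larger than methyl does not by itself go with a lower number; compound 2 goes against any such link. No evidence is available that explains the gap between the 2-fluorophenyl and cyclohexyl groups.

As far as these compounds go, whether the aromatic ring or its fluorine goes with the lower number of compound 2 stays open, and an unsubstituted phenyl would help separate the two. From the compounds shown here alone, how a longer alkyl chain on this nitrogen would read also remains open.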